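Fluoro in Place of Chloro: Expecting Compound 3

This account rests on a few compounds, and the source may have more. Where it says the series, first, only, none or still open, it means among the compounds named here.

Compound 1 `Clc1ccc(-c2csc(N/N=C/c3cccs3)n2)cc1` was tested in a functional assay, read by spectrophotometry, with a stated time of 15 min, tested at 40 ug/mL (on this read-out higher numbers stand for a stronger effect at the one concentration tested and lower numbers for a weaker effect), and gave 83.2%. Of the two numbers shown it is the larger, yet compound 2 `Cc1ccc(-c2csc(N/N=C/c3ccc(Cl)cc3Cl)n2)cc1` gives 80.4% in this assay, a gap within the scatter, so neither stands apart. Compound 3 `Fc1ccc(-c2csc(N/N=C/c3cccs3)n2)cc1` is not yet measured; it differs from compound 1 by fluoro in place of chloro on an aromatic carbon. Among the compounds with values here, no step between measured compounds isolates this change, so the expectation rests on compound 1 alone. The step of a number 6.2 percentage points lower from compound 1 to compound 3 (within the scatter) is expected to stay within the scatter, perhaps a slight easing. Compound 3 is estimated at 77%, between 62% and 90%.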

Compound 3, a percentage reported as inhibition, at one concentration (the size of the read-out at that concentration, not a potency): 87.5%
Compound 3: middle estimate off by 10.5 percentage points, on the low side; measured number inside the range.
By their numbers in this assay, from the lowest: compounds 2, 1 and 3 (each within the scatter of the next).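

In this assay, fluoro in place of chloro on an aromatic carbon, para to a large group, gives a number 4.3 percentage points higher from compound 1 to compound 3 (within the scatter) and is the first single change shown at this position. The read-out therefore does not separate fluoro from chloro here, and the result stays high with either group. No measurement shown bears on what lies behind this.

As far as these compounds go, whether an amine, a carboxylic acid or a longer chain at this place would keep the read-out stays open. So does whether the compounds would show a stronger or weaker effect at any other concentration: each was tested at only one concentration.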